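Silylating the hydroxyl of compound 1: what cytotoxicity to expect

The source may report more compounds than this note shows. Statements on the series, on what has been measured and on what is new or still open speak of the compounds shown alone.

Measured compounds:
- compound 1, `COc1cc(C2=C(c3cc(C)c(OC)c(C)c3)C(O)CC2=O)cc(OC)c1OC`: > 100 ug/mL
- compound 2, `CCOC(=O)COc1ccc(C2=C(c3cc(OC)c(OC)c(OC)c3)C(=O)CC2O)cc1`: > 100 ug/mL

Compound 1 has been tested in an ADME assay on ECV-304 cells (Homo sapiens) for cytotoxicity, read by MTT assay, with a stated time of 72 h; a lower number here means a stronger inhibitor, a higher number a weaker inhibitor. For compound 1 the result > 100 ug/mL is a limit of the assay, not a number. For compound 2 the result > 100 ug/mL is likewise a limit. So compound 1 stands at the limit of > 100 ug/mL in this assay, at which 2 of the 2 values shown sit, and no measured value places it above or below any other compound.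

Compound 3, `COc1cc(C2=C(c3cc(C)c(OC)c(C)c3)C(O[SiH2]C(C)(C)C)CC2=O)cc(OC)c1OC`, has not yet been tested in this assay. It differs from compound 1 by a group of 5 heavy atoms (4 carbon, 1 silicon; no ring) in place of a hydrogen atom, on an oxygen on a saturated carbon.

Among the measured compounds shown here, no step between measured compounds is known, so the size of the step from compound 1 to compound 3 cannot be read from the data. Compound 3 is expected to remain near the limit, with an estimate of 120 ug/mL (range 40 ug/mL to 400 ug/mL), corresponding to an expected step that the limit leaves unreadable from compound 1 to compound 3 not beyond the scatter.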

Compound 3, half-maximal inhibitory concentration: 15 ug/mL
Compound 3: middle estimate off by 8.0-fold (0.90 log units), on the high side, and the stated range ends above it.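

Among the compounds shown here, compound 3 gives the first value in this assay that is a number rather than a limit, so this hydroxyl oxygen on a saturated carbon is a place where a change can move the read-out. Replacing its hydrogen with a group of 5 heavy atoms (4 carbon, 1 silicon; no ring) gives an at least 6.6-fold lower number from compound 1 to compound 3 (0.82 log units; beyond the scatter). This step has only a minimum size, and the earlier compounds offered no readable value to compare with: the limit of > 100 ug/mL in this assay, at which 2 of the 3 values shown sit.

The compounds shown do not tell whether the silicon matters or whether a plain methyl ether or an acetyl ester on the same oxygen would give a similar result. They also leave open whether the same silyl group on the hydroxyl of compound 2 would lower its number.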